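The source may hold more compounds than are shown below. What is called first, only, known or untested is meant among the compounds shown, and "the series" means these compounds.

Measured so far:
Compound 1, `O=c1ccc2cc(OCc3cc(-c4ccccc4)no3)ccc2o1`, gives 43300 nM in a functional assay on HL-60 cells (Homo sapiens) for cytotoxicity, read by MTT assay, with a stated time of 48 h; on this read-out lower numbers stand for stronger inhibition and higher numbers for weaker inhibition.
Compound 2, `O=c1ccc2cc(OCc3cn(-c4ccccc4)nn3)ccc2o1`, gives 41600 nM in this assay.

The two values lie within the usual scatter of each other, so compound 2 cannot be told apart from compound 1 on these numbers alone. Compound 3, `COc1ccccc1-n1cc(COc2ccc3oc(=O)ccc3c2)nn1`, differs from compound 2 by one change: methoxy in place of hydrogen on an aromatic carbon. For the measured compounds named here, no measured pair shows this change, so the step from compound 2 to compound 3 can only be estimated. The expected step is a 1.0-fold lower number from compound 2 to compound 3 (0.02 log units; within the scatter), a change no larger than the scatter. Compound 3 is therefore expected to give about 40000 nM in this assay, within 20000 nM to 80000 nM.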

Compound 3, half-maximal inhibitory concentration: 55200 nM
Estimate against measurement, compound 3: 1.4-fold (0.14 log units) below; measured number inside the range.
By their numbers in this assay, from the lowest: compounds 2, 1 and 3 (each within the scatter of the next).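

For the compounds shown here, the swap of phenyl for 2-methoxyphenyl is the first single-place change that can be read here, and in this assay it amounts to a 1.3-fold higher number from compound 2 to compound 3 (0.12 log units; within the scatter). Compound 2 and compound 3 therefore cannot be told apart, so a methoxy group ortho to a large group leaves no clear mark on this read-out. Nothing available explains this result. Still open, from the compounds shown here alone, is whether an amine, a carboxylic acid or a longer chain in place of the methoxy group would give a clearly different number from compound 2.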